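The source may report more compounds than this note shows. Statements on the series, on what has been measured and on what is new or still open speak of the compounds shown alone.

Measured so far in an ADME assay (liver) for pharmacokinetics, with Liver microsome (Rattus norvegicus) as the target, using microsomes; a higher number here means that the compound lasts longer, a lower number that the compound disappears faster:

compound 1 `CCOc1cc(NC(=O)C2(NC(=O)c3ccc4c(C5CCCC5)c(-c5ncc(Cl)cn5)n(C)c4c3)CCC2)ccc1/C=C/C(=O)OC(=O)C[C@H](O)C(=O)O` — 7.92 h
compound 2 `CCCCCCOC(=O)/C=C/c1ccc(NC(=O)C2(NC(=O)c3ccc4c(C5CCCC5)c(-c5ncc(Cl)cn5)n(C)c4c3)CCC2)cc1OCC` — 12.7 h

For the measured compounds named here, compound 2 carries the higher of the two numbers, but its only neighbour is compound 1, and the step of a 1.6-fold higher number from compound 1 to compound 2 (0.21 log units; within the scatter) lies within the scatter, so the two values are not distinguished by this assay. That step exchanged one ester substituent for another on an oxygen next to a carbonyl group and left the half-life essentially unchanged.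

Compound 3 `CCOc1cc(NC(=O)C2(NC(=O)c3ccc4c(C5CCCC5)c(-c5ncc(Cl)cn5)n(C)c4c3)CCC2)ccc1/C=C/C(=O)OCc1ccccc1` is the next member of the series. Relative to compound 2 the change is phenyl in place of pentyl on a saturated chain carbon bound to an oxygen next to a carbonyl group. Going by the values given here, the single measured step, a 1.6-fold higher number from compound 1 to compound 2 (0.21 log units; within the scatter), is the only one that touches this part of the molecule; it was small, and the present exchange is likewise confined to the ester substituent. No step beyond the scatter is therefore expected for compound 3, the expected step being a 1.3-fold lower number from compound 2 to compound 3 (0.10 log units; within the scatter). The half-life of compound 3 in this assay is estimated at 10 h, with a range of 4 h to 25 h.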

Compound 3, half-life: 2.17 h
Beside the measured number, compound 3's estimate is 4.6-fold (0.66 log units) above it; the measured number lies below the stated range.
By their numbers in this assay, from the lowest: compound 3; then compounds 1 and 2 (each within the scatter of the next).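

The ester substituent is not indifferent in this assay: phenyl in place of pentyl on a saturated chain carbon bound to an oxygen next to a carbonyl group gives a 5.9-fold lower number from compound 2 to compound 3 (0.77 log units; beyond the scatter), a step beyond the scatter. Benzyl in place of (2-carboxy-2-hydroxyethyl)carbonyl gives a 3.6-fold lower number from compound 1 to compound 3 (0.56 log units; beyond the scatter), so the benzyl ester of compound 3 separates from both other esters, although those two substituents could not be told apart. No measurement at hand accounts for this difference.

Going by these compounds, it remains open whether the lower number follows the aromatic ring itself or its single-carbon link to the ester oxygen; a 2-phenylethyl ester and a cyclohexylmethyl ester would separate these two readings. A shorter chain such as an ethyl ester would show how far the hexyl result extends among simple alkyl esters.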